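A few compounds are considered here, and "the series" means these few. Any claim that something is new, unique, unknown or untested is made for them only; others in the source may bear on it.

Of the compounds shown here, two have been measured in a functional assay on cells (Erythrocyte, Homo sapiens) for inhibition, read by spectrophotometry and hemolysis, with a stated time of 10 min; on this read-out lower numbers stand for stronger inhibition and higher numbers for weaker inhibition. Compound 1, with the structure `Cc1cccc2nc(N/N=C\c3ccccc3)sc12`, gives 80.1 ug/mL. Compound 2, with the structure `Cc1cccc2nc(N/N=C\c3ccc(F)cc3)sc12`, gives 32.2 ug/mL, the lowest of the two numbers and therefore the stronger inhibition seen so far. For the measured compounds named here, the single step between them, a 2.5-fold lower number from compound 1 to compound 2 (0.40 log units; beyond the scatter), is modest but beyond the scatter.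

Compound 3, with the structure `Cc1cccc2nc(N/N=C\c3ccc(O)cc3)sc12`, has not yet been measured. It differs from compound 2 in one place: hydroxy in place of fluoro on an aromatic carbon. Going by the values given here, no measured step exchanges a hydroxy for a fluoro, so the only guide is the step from compound 1 to compound 2, which shows that a fluoro at this place lowered the number. Taking the fluoro away again might give part of that back, while the hydroxy is a new group whose effect in this assay is unknown. Compound 3 is therefore expected to land between compound 1 and compound 2, a step of a 1.7-fold higher number from compound 2 to compound 3 (0.23 log units; within the scatter), with an estimated value of 55 ug/mL and a range from 25 ug/mL to 130 ug/mL.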

Compound 3, half-maximal inhibitory concentration: 60 ug/mL
The estimate for compound 3 lay 1.1-fold (0.04 log units) below the measured number; low and high end bracket the measured number.
By their numbers in this assay, from the lowest: compounds 2, 3 and 1 (each within the scatter of the next, the first and the last beyond it).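

In this assay, the group at this place, on an aromatic carbon para to a large group, can now be compared three ways, and putting hydroxy in place of fluoro gives a 1.9-fold higher number from compound 2 to compound 3 (0.27 log units; within the scatter), while putting hydroxy in place of hydrogen gives a 1.3-fold lower number from compound 1 to compound 3 (0.13 log units; within the scatter). For the compounds shown here, neither of these steps can be told apart from the ordinary spread of repeated measurements, so compound 3 cannot be ranked against either of the other two, and the only step here that clears that spread remains a 2.5-fold lower number from compound 1 to compound 2 (0.40 log units; beyond the scatter). A hydroxy at this place therefore shows no clear separation from either fluoro or hydrogen in this read-out, and nothing available explains the differences among these three compounds.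

On these data alone, it remains open whether the step seen with fluoro belongs to fluoro alone or would also appear with chloro, methoxy, an amine or a carboxylic acid at the same place. With only three compounds shown, it also remains open how a longer chain at this place would read in this assay.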